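A few compounds are considered here, and "the series" means these few. Any claim that something is new, unique, unknown or untested is made for them only; others in the source may bear on it.

Measured so far:
compound 1 `N#Cc1ccc(NC(=O)c2cc(F)ccc2O)cc1` gives 2670 nM in a functional assay on KG-1 cells (Homo sapiens) for cytotoxicity, read by luminescence and CellTiter-Glo, with a stated time of 3 days; on this read-out higher numbers stand for weaker inhibition and lower numbers for stronger inhibition
compound 2 `O=C(Nc1ccc(C(F)(F)F)cc1)c1cc(F)ccc1O` gives 1700 nM in this assay

Going by the values given here, compound 1 stands as the higher of the two numbers in this assay; its only neighbour is compound 2, reached by a 1.6-fold lower number from compound 1 to compound 2 (0.20 log units; within the scatter), a step that lies within the scatter, so the two compounds cannot be ordered. Compound 3 `N#Cc1ccc(NC(=O)c2cc(Br)ccc2O)cc1` differs from compound 1 by bromo in place of fluoro on an aromatic carbon. Among the compounds with values here, no measured step touches this change: the single step from compound 1 to compound 2 alters the cyano group and leaves the fluoro untouched, and no other compound carries a bromo. There is therefore no measured ground for expecting a step beyond the scatter in this assay, in either direction, and the estimate for compound 3 is anchored on compound 1 with a wide range. Compound 3 is accordingly estimated at 2000 nM (range 700 nM to 6000 nM), which amounts to an expected 1.3-fold lower number from compound 1 to compound 3 (0.13 log units; within the scatter).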

Compound 3, half-maximal inhibitory concentration: 1290 nM
Compound 3: the middle estimate sits 1.6-fold (0.19 log units) above what was measured, and the stated range covers the measured number.
By their numbers in this assay, from the lowest: compounds 3, 2 and 1 (each within the scatter of the next, the first and the last beyond it).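

At the aromatic carbon para to a hydroxy group, the halogen can be exchanged with a measurable effect: in this assay, bromo in place of fluoro gives a 2.1-fold lower number from compound 1 to compound 3 (0.32 log units; beyond the scatter), a modest step but the only one shown so far beyond the scatter. Going by these compounds alone, the earlier step, a 1.6-fold lower number from compound 1 to compound 2 (0.20 log units; within the scatter), stayed within the scatter and left this position untouched, so this is the first reading of the position and the first step that can be ordered. Nothing measured here accounts for the step.

From the compounds shown here alone, with a single pair at this position, it remains open whether the trend extends to chloro, iodo, a methyl group or an amine. Also open, going by these compounds, is whether bromo in place of fluoro gives a similar step when trifluoromethyl replaces cyano, as on compound 2.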